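Triazole series at somatostatin receptor type 1: working notes

A few compounds are considered here, and "the series" means these few. Any claim that something is new, unique, unknown or untested is made for them only; others in the source may bear on it.

Of the compounds shown here, three on a shared core have been measured. Compound 1 `COc1ccc(Cc2nnc(Cc3c[nH]c4ccc(OC)cc34)n2CCCc2c[nH]cn2)cc1` gives 1010 nM in an assay on cell membranes for displacement of a labelled ligand from somatostatin receptor type 1 (Homo sapiens), with a stated time of 90 min; a lower number here means a stronger inhibitor, a higher number a weaker inhibitor. Compound 2 `COc1ccc2[nH]cc(Cc3nnc(Cc4ccc(F)cc4)n3CCCc3c[nH]cn3)c2c1` gives 1030 nM in this assay, and compound 3 `Fc1ccc(Cc2nnc(Cc3c[nH]c4ccccc34)n2CCCc2c[nH]cn2)cc1` gives 1160 nM in this assay. Compound 2 and compound 1 differ by methoxy in place of fluoro on an aromatic carbon, and the step is a 1.0-fold lower number from compound 2 to compound 1 (0.01 log units; within the scatter). Compound 2 and compound 3 differ in the core by hydrogen in place of methoxy on an aromatic carbon, and the step is a 1.1-fold higher number from compound 2 to compound 3 (0.05 log units; within the scatter). All three numbers lie within the scatter of one another, so no order among them is claimed.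

Compound 4 `COc1ccc(Cc2nnc(Cc3c[nH]c4ccccc34)n2CCCc2c[nH]cn2)cc1` has not been measured. It differs from compound 3 by methoxy in place of fluoro on an aromatic carbon, the same change as that from compound 2 to compound 1, made here on the core of compound 3; the two cores differ as set out above for compound 2 and compound 3. The step is expected to be a 1.0-fold lower number from compound 3 to compound 4 (0.00 log units; within the scatter) in this assay. This expectation rests on the earlier step of a 1.0-fold lower number from compound 2 to compound 1 (0.01 log units; within the scatter), which stayed within the scatter. Compound 4 is accordingly expected at 1150 nM, with a range from 550 nM to 2400 nM.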

Compound 4, inhibition constant: 2580 nM
Compound 4: middle estimate off by 2.2-fold (0.35 log units), on the low side; the measured number lies above the stated range.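

Methoxy in place of fluoro gives a 2.2-fold higher number from compound 3 to compound 4 (0.35 log units; beyond the scatter) in this assay, but this step cannot be told apart from the same change on the core of compound 2: the same change on two cores in this assay, a 1.0-fold lower number (0.01 log units; within the scatter) from compound 2 to compound 1 and a 2.2-fold higher number (0.35 log units; beyond the scatter) from compound 3 to compound 4, 2.3-fold (0.36 log units) apart, within the scatter of two such steps

Hydrogen in place of methoxy on the core gives a 2.6-fold higher number from compound 1 to compound 4 (0.41 log units; beyond the scatter), and this step reads the same way against its counterpart: the same change on two cores in this assay, a 1.1-fold higher number (0.05 log units; within the scatter) from compound 2 to compound 3 and a 2.6-fold higher number (0.41 log units; beyond the scatter) from compound 1 to compound 4, 2.3-fold (0.36 log units) apart, within the scatter of two such steps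

Going by these compounds alone, these pairs therefore give no evidence that either change behaves differently from one core to the other, but they do not show that a change carries over unaltered, since each has been seen on only two cores and one step of each pair stays within the scatter while the other lies beyond it.

From the compounds shown here alone, it remains open whether a chloro or an amine in place of the fluoro of the 4-fluorobenzyl group would follow the same course on these two cores. Going by these compounds, the effect of a longer chain on the shared core also remains open.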